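A few compounds are considered here, and "the series" means these few. Any claim that something is new, unique, unknown or untested is made for them only; others in the source may bear on it.

For the measured compounds named here, in an assay on isolated protein for inhibition of Amine oxidase [flavin-containing] A (Homo sapiens), read by fluorescence, with a stated time of 20 min (on this read-out higher numbers stand for weaker inhibition and lower numbers for stronger inhibition), compound 2 `CC/C(C)=N\Nc1nc(-c2cccc([N+](=O)[O-])c2)cs1` gives 20500 nM, the highest of the three numbers measured so far. Compound 1 `CC(C)=NNc1nc(-c2cccc([N+](=O)[O-])c2)cs1` gives 1070 nM, and compound 3 `C/C(CC(C)C)=N/Nc1nc(-c2cccc([N+](=O)[O-])c2)cs1` gives 4410 nM. Every step among these three lies beyond the scatter: a 19-fold higher number from compound 1 to compound 2 (1.28 log units; beyond the scatter), a 4.1-fold higher number from compound 1 to compound 3 (0.62 log units; beyond the scatter) and a 4.6-fold lower number from compound 2 to compound 3 (0.67 log units; beyond the scatter). Compound 4 `C=CCC/C(C)=N\Nc1nc(-c2cccc([N+](=O)[O-])c2)cs1` differs from compound 2 by vinyl in place of hydrogen on a saturated chain carbon, two bonds along the chain from a carbon with a double bond to nitrogen. Going by the values given here, no measured step changes this same place; the closest guide is the exchange of isopropyl for methyl on a saturated chain carbon bound to a carbon with a double bond to nitrogen, which lowered the number, while the move from hydrogen to methyl at that carbon raised it sharply. Because a 4.6-fold lower number from compound 2 to compound 3 (0.67 log units; beyond the scatter) went toward a lower number as the chain grew, the expected step for compound 4 is estimated as a 2.3-fold lower number from compound 2 to compound 4 (0.36 log units; beyond the scatter), though with wide uncertainty. Compound 4 is therefore estimated at 9000 nM, within a range of 2500 nM to 30000 nM.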

Compound 4, half-maximal inhibitory concentration: 3990 nM
Compound 4: middle estimate off by 2.3-fold (0.35 log units), on the high side; low and high end bracket the measured number.
By their numbers in this assay, from the lowest: compound 1; then compounds 4 and 3 (each within the scatter of the next); then compound 2.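

Ethyl to but-3-en-1-yl at this place gives a 5.1-fold lower number from compound 2 to compound 4 (0.71 log units; beyond the scatter), so in this assay a longer unbranched chain takes the number well back down from its high point at the ethyl of compound 2. Allyl in place of isopropyl gives a 1.1-fold lower number from compound 3 to compound 4 (0.04 log units; within the scatter), so the two larger groups cannot be told apart here, and the rise from hydrogen to methyl does not continue as the group grows. Even so, allyl in place of hydrogen gives a 3.7-fold higher number from compound 1 to compound 4 (0.57 log units; beyond the scatter), which leaves compound 1 with the lowest number of the four.

Nothing available explains this uneven course with chain size. As far as these compounds go, whether a saturated butyl chain would read like the but-3-en-1-yl chain, and how an amine at the chain end would read, stay open.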